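Swapping Pyrimidine for Thiazole on an Inactive Sulfonamide

This account rests on a few compounds, and the source may have more. Where it says the series, first, only, none or still open, it means among the compounds named here.

Compound 1 `O=C1/C(=C/c2coc3ccccc3c2=O)N=C(c2ccccc2)N1c1ccc(S(=O)(=O)Nc2ncccn2)cc1` was tested in a functional assay on MCF7 cells (Homo sapiens) for cytotoxicity, read by sulforhodamine B assay, with a stated time of 72 h; on this read-out higher numbers stand for weaker inhibition and lower numbers for stronger inhibition. Compound 1 gives only the limit > 100000 nM, not a number. A second compound of a different make-up, compound 2 `CCOC1Oc2ccccc2C(=O)/C1=C/Nc1ccc(S(N)(=O)=O)cc1`, gives 22200 nM in this assay. Compound 3 `O=C1/C(=C/c2coc3ccccc3c2=O)N=C(c2ccccc2)N1c1ccc(S(=O)(=O)Nc2nccs2)cc1` differs from compound 1 by 1,3-thiazol-2-yl in place of pyrimidin-2-yl on a sulfonamide nitrogen. With compound 1 sitting at the limit (the limit of > 100000 nM in this assay, at which 1 of the 2 values shown sits), the swap of one small aromatic ring for another gives no grounds to expect a measurable step, so the expected change a number no higher from compound 1 to compound 3 (the limit leaves the size open) is none beyond the scatter. Compound 3 is therefore estimated at 100000 nM, within 30000 nM to 300000 nM.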

Compound 3, half-maximal inhibitory concentration: 88500 nM
Compound 3: middle estimate off by 1.1-fold (0.05 log units), on the high side; the range from low to high includes it.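

In this assay, 1,3-thiazol-2-yl in place of pyrimidin-2-yl on a sulfonamide nitrogen gives an at least 1.1-fold lower number from compound 1 to compound 3 (0.05 log units; that floor lies within the scatter). This shared core now has a measured number in compound 3, 88500 nM, but the true size of the step cannot be fixed: the limit of > 100000 nM in this assay, at which 1 of the 3 values shown sits.

As far as these compounds go, it remains open whether a ring is needed on this nitrogen at all, or whether an acetyl or methyl group there would change the number on this core. A pyridin-2-yl ring in the same place is also an open case.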